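Amide cap truncation in the valine piperidine series

The source may hold more compounds than are shown below. What is called first, only, known or untested is meant among the compounds shown, and "the series" means these compounds.

Measured:
compound 1, `CC(C)[C@@H](NC(=O)CCCc1ccccc1)C(=O)N1CCC(c2ccc(Cl)cc2)CC1` — 95 nM in an assay on THP-1 cells for displacement of a labelled ligand from C-C chemokine receptor type 1 (Homo sapiens); on this read-out higher numbers stand for weaker inhibition and lower numbers for stronger inhibition
compound 2, `Cc1ccccc1C(=O)NC(C(=O)N1CCC(c2ccc(Cl)cc2)CC1)C(C)C` — 36 nM in this assay

Compound 1 stands at the higher of the two numbers in this assay; compound 2 sits lower by a margin beyond the usual scatter. Going by the values given here, no single-change pair has been measured, so the size of any one replacement is not yet known.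

Compound 3, `CC(C)[C@@H](NC(=O)CC1CC1)C(=O)N1CCC(c2ccc(Cl)cc2)CC1`, keeps the shared core of compound 1 and changes only the amide cap: cyclopropyl in place of phenethyl on a saturated chain carbon bound to a carbonyl carbon. On these data alone, the phenethyl of compound 1 and the aromatic cap of compound 2 both give numbers in the double-digit range; a smaller cap is untested. The expectation is a step toward weaker inhibition in this assay, a 3.2-fold higher number from compound 1 to compound 3 (0.50 log units; beyond the scatter), likely beyond the scatter. Compound 3 is estimated at 300 nM, with a range from 100 nM to 1000 nM.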

Compound 3, half-maximal inhibitory concentration: 46 nM
For compound 3 the middle estimate is 6.5-fold (0.81 log units) above the measured one; measured number outside the range, below it.
By their numbers in this assay, from the lowest: compounds 2 and 3 (each within the scatter of the next); then compound 1.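

Going by these compounds alone, with a single change on a saturated chain carbon bound to a carbonyl carbon, cyclopropyl in place of phenethyl gives a 2.1-fold lower number from compound 1 to compound 3 (0.31 log units; beyond the scatter) in this assay, the first size reading for this position and a modest step. The cap position therefore accepts the removal of the six-membered aromatic ring, with 8 heavy atoms reduced to 3, and inhibition does not weaken. Nothing at hand accounts for the direction of this step.

The change from 3-phenylpropyl to cyclopropylmethyl alters the ring and the chain together, so the contribution of each remains unresolved. Also open, on these data alone, is how a cap carrying an amine or a carboxylic acid, or a plain unbranched alkyl chain without any ring, would read at this position.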